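This account rests on a few compounds, and the source may have more. Where it says the series, first, only, none or still open, it means among the compounds named here.

Measured so far in an assay on HEK293 cells for displacement of a labelled ligand from Melanocortin receptor 4 (Homo sapiens); on this read-out lower numbers stand for stronger inhibition and higher numbers for weaker inhibition:

compound 1, `NC(COCc1ccccc1)c1cc(F)ccc1N1CCN(C(=O)CCc2ccc(Cl)cc2Cl)CC1`: 1000 nM
compound 2, `Cc1[nH]c2ccccc2c1CCC(=O)N1CCN(c2ccc(C(F)(F)F)cc2[C@@H](N)CC(C)C)CC1`: 1600 nM
compound 3, `CCN[C@H](c1cc(C(F)(F)F)ccc1N1CCN(C(=O)CCc2ccc(Cl)cc2Cl)CC1)C(C)CC`: 92 nM

Among these three numbers, compound 1 stands second highest. Compound 2 gives a number close to that of compound 1, within the usual scatter of the measurement, whereas compound 3 gives a much lower number, a gap that lies beyond the scatter.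

Compound 4, `NCCC(=O)NC(COCc1ccccc1)c1cc(F)ccc1N1CCN(C(=O)CCc2ccc(Cl)cc2Cl)CC1`, has not yet been measured. It differs from compound 1 in a single place: (2-aminoethyl)carbonyl in place of hydrogen on an amine nitrogen. Within the data shown here, no measured pair of compounds shows this same change, so nothing here tells how large its effect will be. The step of a 1.5-fold higher number from compound 1 to compound 4 (0.18 log units; within the scatter) is expected to be modest, toward a somewhat higher number, and it may well stay within the scatter. For compound 4 the expected value in this assay is estimated at 1500 nM, with a range from 400 nM to 6000 nM.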

Compound 4, inhibition constant: 210 nM
Beside the measured number, compound 4's estimate is 7.1-fold (0.85 log units) above it, outside the stated range (below it).
By their numbers in this assay, from the lowest: compound 3; then compound 4; then compounds 1 and 2 (each within the scatter of the next).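

In this assay, putting (2-aminoethyl)carbonyl in place of hydrogen on the amine nitrogen gives a 4.8-fold lower number from compound 1 to compound 4 (0.68 log units; beyond the scatter) and so strengthens inhibition. This amine nitrogen therefore need not keep that hydrogen, and this added chain is accepted here. Nothing available explains why the number falls.

The compounds shown leave open whether the step comes from the carbonyl or from the chain's end amino group. An acetyl group on the same nitrogen, or a longer chain ending in an amine, would help separate the two.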